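The source may hold more compounds than are shown below. What is called first, only, known or untested is meant among the compounds shown, and "the series" means these compounds.

Compound 1 `Cc1cc(C)c2c(O)cc(-c3cccc4ccccc34)nc2n1` and compound 3 `Cc1cc(C)c2c(O)cc(-c3ccc4ccccc4c3)nc2n1` carry two methyl groups on the shared core, while compound 2 `Cc1ccc2c(O)cc(-c3cccc(Cl)c3)nc2n1` carries one. In a functional assay on PC-3 cells (Homo sapiens) for antiproliferative activity (a higher number here means a weaker inhibitor of growth, a lower number a stronger inhibitor of growth), compound 1 gives 759 nM and compound 3 gives 5500 nM. Compound 2 reaches only the limit of this assay, > 100000 nM, which is a boundary and not a number (the limit of > 100000 nM in this assay, at which 1 of the 3 values shown sits). Compound 4 `Cc1cccc(-c2cc(O)c3ccc(C)nc3n2)c1` differs from compound 2 by methyl in place of chloro on an aromatic carbon, the methyl standing meta to a large group. Among the measured compounds shown here, no measured pair shows this change, so no step guides it. The step from compound 2 to compound 4 is expected to stay within the scatter, leaving compound 4 close to the limit, an at least 1.2-fold lower number from compound 2 to compound 4 (0.09 log units; that floor lies within the scatter). Compound 4 is estimated at 80000 nM, with a range from 15000 nM to 300000 nM.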

Compound 4, concentration for 50% growth inhibition: 138 nM
Beside the measured number, compound 4's estimate is 580-fold (2.76 log units) above it; the whole stated range lies above it.
By their numbers in this assay, from the lowest: compound 4; then compound 1; then compound 3. At a limit, above all of these: compound 2.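

On an aromatic carbon, meta to a large group, methyl in place of chloro gives an at least 720-fold lower number from compound 2 to compound 4 (2.86 log units; beyond the scatter) in this assay. Among the compounds shown here, this is the first step between measured compounds that differ in one place, and it shows that the group at this position can matter greatly for growth inhibition. The value for compound 2 is a limit and not a number: the limit of > 100000 nM in this assay, at which 1 of the 4 values shown sits.

As far as these compounds go, the full size of the step therefore stays open. So does how a methoxy, an amine or a longer chain at this position would compare with methyl and chloro.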